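Lengthening the hydroxycarbamoyl chain of compound 1

This account rests on a few compounds, and the source may have more. Where it says the series, first, only, none or still open, it means among the compounds named here.

In a functional assay on HeLa cells (Homo sapiens) for inhibition, read by MTT assay, with a stated time of 72 h (on this read-out higher numbers stand for weaker inhibition and lower numbers for stronger inhibition), compound 1 `Nc1nc2cc(-c3nn(CCCCC(=O)NO)c4ncnc(N)c34)ccc2o1` gives 32200 nM. For the measured compounds named here, this is the only number, so compound 1 cannot yet be ranked against another compound. Compound 2 `Nc1ncnc2c1c(-c1cnc3[nH]ccc3c1)nn2CCC(=O)NO` offers no comparison, since the entry for compound 2 reads "not determined" (no result reported).

Compound 3 `Nc1nc2cc(-c3nn(CCCCCCC(=O)NO)c4ncnc(N)c34)ccc2o1` keeps the core of compound 1 and differs only in its chain: 2-(hydroxycarbamoyl)ethyl in place of hydroxycarbamoyl on a saturated chain carbon, four bonds along the chain from an aromatic nitrogen. The change places 2-(hydroxycarbamoyl)ethyl in place of hydroxycarbamoyl on a saturated chain carbon, four bonds along the chain from an aromatic nitrogen.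

Going by the values given here, no measured pair isolates chain length, so the expectation rests on a single number and carries wide margins. With compound 1 at 32200 nM, there is ample room on the scale for stronger inhibition, and a change in that direction is the working assumption. The expected change is an 8.1-fold lower number from compound 1 to compound 3 (0.91 log units; beyond the scatter), a step beyond the scatter of this assay towards lower numbers, though a smaller step would not be surprising. For compound 3 the estimated value is 4000 nM, with an expected range of 800 nM to 20000 nM.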

Compound 3, half-maximal inhibitory concentration: 6410 nM
For compound 3 the middle estimate is 1.6-fold (0.20 log units) below the measured one; the range from low to high includes it.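

In this assay the longer chain gives a 5.0-fold lower number from compound 1 to compound 3 (0.70 log units; beyond the scatter), so this position responds to a change in chain length, which the lone value of compound 1 could not show. With the core of compound 1 unchanged, the step can be placed on a single site: 2-(hydroxycarbamoyl)ethyl in place of hydroxycarbamoyl on a saturated chain carbon, four bonds along the chain from an aromatic nitrogen. No supporting data on hand bear on what lies behind this step.

With a single pair, the direction holds only for compound 1 and compound 3 and cannot yet be called a trend along the chain. Still open, on these data alone, are whether a longer chain carrying the same hydroxycarbamoyl end lowers the number further or reverses the step, and whether a carboxylic acid or a primary amide at the chain end retains any of the inhibition seen with compound 3.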